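This account rests on a few compounds, and the source may have more. Where it says the series, first, only, none or still open, it means among the compounds named here.

Measured compounds:
compound 1 `O=c1[nH]c(=O)n([C@@H]2O[C@H](CO)[C@@H](O)[C@H]2O)cc1C#CC(O)c1ccccc1`, 34200 nM
compound 2 `CCCCCCC#Cc1c[nH]c(=O)[nH]c1=O`, 249000 nM

In an ADME assay on A549 cells (Homo sapiens) for cytotoxicity, read by MTT assay (a higher number here means that more compound is tolerated, a lower number that less compound is tolerated), compound 1 gives 34200 nM and compound 2 gives 249000 nM. Compound 2 holds the higher of the two numbers; the gap to compound 1 lies beyond the scatter, so compound 2 is the better tolerated of the pair. Among the measured compounds shown here, the two structures differ in more than one place and no single step joins them, so the comparison yields nothing beyond the two values themselves.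

Compound 3 `CCCCC#Cc1c[nH]c(=O)[nH]c1=O` has not yet been measured in this assay. It differs from compound 2 in one place: hydrogen in place of ethyl on a saturated chain carbon, four bonds along the chain from a triple-bonded carbon. The shared core is untouched; the change is confined to the chain. For the measured compounds named here, no measured pair isolates this change, so the expectation rests on the one neighbour, compound 2, and on the smallness of the alteration. In this assay the expected step is a 1.2-fold higher number from compound 2 to compound 3 (0.08 log units; within the scatter), a shift not clearly beyond the scatter and with no firm direction. Compound 3 is therefore estimated at 300000 nM, with a range from 120000 nM to 800000 nM.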

Compound 3, half-maximal cytotoxic concentration: 250000 nM
Estimate against measurement, compound 3: 1.2-fold (0.08 log units) above; measured number inside the range.
By their numbers in this assay, from the lowest: compound 1; then compounds 2 and 3 (each within the scatter of the next).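

In this assay the series gains its first step that changes one place only, and it reads a 1.0-fold higher number from compound 2 to compound 3 (0.00 log units; within the scatter): hydrogen in place of ethyl on a saturated chain carbon, four bonds along the chain from a triple-bonded carbon, gives no shift beyond the scatter. At this position, then, removing the ethyl leaves the tolerated concentration unchanged within the scatter, which the earlier pair, differing in more than one place, could not show. Nothing available explains this flat step, and no cause can be assigned to it.

From the compounds shown here alone, whether the flat reading extends to other changes at this place remains open, since a longer chain, or a chain ending in an amine or a carboxylic acid, may or may not leave the number where it stands. Compound 1 is joined to the other two by no single change, so what separates its number from theirs also stays unresolved.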